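Azetidine in place of cyclobutylamine on a quinoline amide

This account rests on a few compounds, and the source may have more. Where it says the series, first, only, none or still open, it means among the compounds named here.

Of the compounds shown here, two from this series have been measured in an assay on isolated protein for displacement of a labelled ligand from melanin-concentrating hormone receptor 1 (Homo sapiens); a higher number here means a weaker inhibitor, a lower number a stronger inhibitor. Compound 1 `CCCc1cc(NC2CCC2)c2cc(NC(=O)/C=C/c3ccc(C(F)(F)F)cc3)ccc2n1` gives 18 nM in this assay. Compound 2 `CCCc1cc(N)c2cc(NC(=O)c3ccc(-c4ccc(Cl)cc4)cc3)ccc2n1`, which carries a free amino group and a different amide, gives 0.7 nM in this assay. Among the measured compounds shown here, of the two numbers, that of compound 1 is the higher, and the gap to compound 2 is well beyond the usual scatter of repeated measurements; since the two differ in more than one place, no single step can be drawn from that gap.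

Compound 3 `CCCc1cc(N2CCC2)c2cc(NC(=O)/C=C/c3ccc(C(F)(F)F)cc3)ccc2n1` has not yet been measured. It differs from compound 1 in one place only: azetidin-1-yl in place of cyclobutylamino on an aromatic carbon. The change removes the hydrogen-bond donor of the cyclobutylamino group while the four-membered ring is kept.

For the measured compounds named here, with no measured pair that isolates this change, the expected step from compound 1 to compound 3 is estimated as a 1.6-fold higher number from compound 1 to compound 3 (0.19 log units; within the scatter), that is, no change beyond the scatter or a slight weakening. For compound 3 the value in this assay is therefore expected at 28 nM, within a range from 8 nM to 100 nM.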

Compound 3, half-maximal inhibitory concentration: 2.8 nM
Estimate against measurement, compound 3: 10-fold (1.00 log units) above, outside the stated range (below it).
By their numbers in this assay, from the lowest: compound 2; then compound 3; then compound 1.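

In this assay, azetidin-1-yl in place of cyclobutylamino on the aromatic carbon opposite the ring nitrogen gives a 6.4-fold lower number from compound 1 to compound 3 (0.81 log units; beyond the scatter). Among the compounds shown here, this is the first single-place step, and it shows that the number at this position responds to the choice of amine, and that a low number does not depend on the hydrogen-bond donor of the cyclobutylamino group, at least with the amide of compound 1 in place. The entering group both lacks that donor and has fewer heavy atoms, this one step cannot separate those two differences, and nothing measured here explains why the number falls.

The compounds shown leave open whether other ring or open-chain amines at this position, such as pyrrolidin-1-yl, piperidin-1-yl or dimethylamino, would follow azetidin-1-yl or cyclobutylamino. For the compounds shown here, they also leave open whether the same change would produce a step of similar size on a different amide, such as the one carried by compound 2, whose amino group at this position is free.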